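Orexin-2 agonist series: amide nitrogen methyl to hydrogen

The source may hold more compounds than are shown below. What is called first, only, known or untested is meant among the compounds shown, and "the series" means these compounds.

Measured compounds:
compound 1 `COc1ccc(-c2cccc(C(=O)N(C)C)c2)cc1S(=O)(=O)Nc1cccc(NCC(C)NC(=O)c2cccc(C)c2)c1`, 82%
compound 2 `COc1ccc(-c2csc(C(=O)N(C)C)c2)cc1S(=O)(=O)Nc1cccc(NCCNC(=O)c2cccc(C)c2)c1`, 68%
compound 3 `COc1ccc(-c2cccc(C(=O)N(C)CCN(C)C)c2)cc1S(=O)(=O)Nc1cccc(NCCNC(=O)c2cccc(C)c2)c1`, 85%

In a functional assay on CHO-RD-HGA16 cells for agonist activity at Orexin receptor type 2 (Homo sapiens), read by fluorescence and calcium flux, with a stated time of 30 min (a higher number here means a larger maximal response, a lower number a smaller maximal response), compound 3 gives the highest of the three numbers. Compound 1 sits close to it, within the usual scatter, so no order between compound 1 and compound 3 can be read. Compound 2 lies further down, beyond the scatter.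

Compound 4 `COc1ccc(-c2cccc(C(=O)NCCN(C)C)c2)cc1S(=O)(=O)Nc1cccc(NCCNC(=O)c2cccc(C)c2)c1` is not yet measured. It differs from compound 3 in one place: hydrogen in place of methyl on an amide-type nitrogen.

Among the compounds with values here, no step between measured compounds is available to calibrate this change. The step of a number 5 percentage points lower from compound 3 to compound 4 (within the scatter) is therefore expected to stay within the scatter, in no clear direction. For compound 4 in this assay the estimate is 80%, with a range from 65% to 95%.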

Compound 4, largest response reached (Emax), in percent of the reference or control that the assay uses: 64%
Beside the measured number, compound 4's estimate is 16 percentage points above it, and the stated range ends above it.
By their numbers in this assay, from the lowest: compounds 4 and 2 (each within the scatter of the next); then compounds 1 and 3 (each within the scatter of the next).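

In this assay, within the data shown here, the methyl on the amide-type nitrogen proves to matter: hydrogen in its place gives a number 21 percentage points lower from compound 3 to compound 4 (beyond the scatter), the first calibrated step. A change of one carbon at this nitrogen is thus enough to lower the maximal response beyond the scatter. Nothing available on these compounds accounts for the step.

From the compounds shown here alone, whether an ethyl or a cyclopropyl on this nitrogen would hold the response of compound 3 stays open. So does whether a longer chain in place of the 2-(dimethylamino)ethyl group would change the effect of the methyl.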